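Aryl selenocyanate and diselenide carbamates: extending the alkyl chain

The source may report more compounds than this note shows. Statements on the series, on what has been measured and on what is new or still open speak of the compounds shown alone.

Measured so far:
- compound 1, `CC(C)COC(=O)Nc1ccc([Se]C#N)cc1`: in a functional assay on CCRF-CEM cells (Homo sapiens) for cytotoxicity, read by MTT assay, with a stated time of 72 h (on this read-out higher numbers stand for weaker inhibition of growth and lower numbers for stronger inhibition of growth), compound 1 gives 9300 nM
- compound 2, `CCCCCCOC(=O)Nc1ccc([Se][Se]c2ccc(NC(=O)OCCCCCC)cc2)cc1`: in this assay compound 2 gives 6200 nM
- compound 3, `Cc1ccc(OC(=O)Nc2ccc([Se][Se]c3ccc(NC(=O)Oc4ccc(C)cc4)cc3)cc2)cc1`: in this assay compound 3 gives 21400 nM

Compound 1 stands second highest of the three numbers. Its nearest neighbour is compound 2, whose number is lower but within the scatter, so the two cannot be told apart. Compound 3, the aryl carbamate diselenide, gives the highest number, and its gap to compound 1 lies beyond the scatter. Within the data shown here, no two of the three compounds differ in a single place, so no step between measured compounds is available.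

Compound 4, `CCCCCCOC(=O)Nc1ccc([Se]C#N)cc1`, is not yet measured. It differs from compound 1 by pentyl in place of isopropyl on a saturated chain carbon bound to an oxygen next to a carbonyl group. The only other hexyl carbamate in the set, compound 2, carries a diselenide rather than a selenocyanate, so it does not supply a direct comparison. Among the measured compounds shown here, with no measured step of this kind, the expected step of a 1.2-fold lower number from compound 1 to compound 4 (0.09 log units; within the scatter) in this assay is small and not beyond the scatter in either direction. Compound 4 is therefore estimated at 7500 nM, with a range from 3000 nM to 20000 nM.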

Compound 4, concentration for 50% growth inhibition: 19700 nM
Estimate against measurement, compound 4: 2.6-fold (0.42 log units) below, and the stated range covers the measured number.
By their numbers in this assay, from the lowest: compounds 2 and 1 (each within the scatter of the next); then compounds 4 and 3 (each within the scatter of the next).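

Pentyl in place of isopropyl on a saturated chain carbon bound to an oxygen next to a carbonyl group gives the first readable step at this position: in this assay the selenocyanate series shows a 2.1-fold higher number from compound 1 to compound 4 (0.33 log units; beyond the scatter). The position is therefore not silent to the make-up of the carbamate chain, and in this one pair the hexyl chain goes with weaker inhibition of growth than the isobutyl chain, a modest change that is still beyond the scatter. Nothing available bears on the reason for this step.

Open, from the compounds shown here alone, is whether the number climbs steadily with chain length or whether the step reflects the loss of the branch, which a straight butyl or an octyl chain at this position would help to separate. Also open, going by these compounds, is whether the same change carries over to the diselenides, where an isobutyl carbamate diselenide would form a single-place pair with compound 2.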